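Mirror-Image Bicyclic Lactone Tested on Mouse Fibroblasts

This account rests on a few compounds, and the source may have more. Where it says the series, first, only, none or still open, it means among the compounds named here.

Compound 3 `CC1(C)[C@H]2CC3=NCC(=O)O[C@]3(C)[C@@H]1C2` was tested in an ADME assay on NIH3T3 cells (Mus musculus) for antiproliferative activity, read by sulforhodamine B assay, with a stated time of 48 h (on this read-out lower numbers stand for stronger inhibition and higher numbers for weaker inhibition), where compound 3 gives > 2000000 nM, a limit of the assay rather than a number. Compound 1 `CC1(C)[C@@H]2CC3=N[C@@H](CCC(=O)O)C(=O)O[C@@]3(C)[C@H]1C2` gives > 1200000 nM in this assay, also a limit. Compound 2 `C[C@@H]1N=C2C[C@@H]3C[C@@H](C3(C)C)[C@]2(C)OC1=O` gives > 2000000 nM in this assay, again a limit. The step that the two limits leave unreadable from compound 1 to compound 2 stays unreadable; both values are limits, which the limit of > 1200000 nM in this assay, at which 1 of the 3 values shown sits, and the limit of > 2000000 nM in this assay, at which 2 of the 3 values shown sit, record.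

Compound 4 `CC1(C)[C@@H]2CC3=NCC(=O)O[C@@]3(C)[C@H]1C2` differs from compound 3 only in configuration: the two compounds have the same atoms and bonds and differ only in configuration as drawn: 3 of 3 stereo elements differ (all stereocentres are inverted: mirror images); a stereocentre at a saturated ring carbon is drawn R in compound 3 and S in compound 4; a stereocentre at a saturated ring carbon is drawn R in compound 3 and S in compound 4; a stereocentre at a saturated ring carbon is drawn R in compound 3 and S in compound 4. For the measured compounds named here, no measured step changes configuration alone, so none bears directly on this change, and no shift beyond the scatter is expected. Compound 4 is expected to give 3000000 nM in this assay, within 1000000 nM to 20000000 nM, most likely as a limit again. The expected step that the limit leaves unreadable from compound 3 to compound 4 is therefore estimated as essentially none.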

Compound 4, half-maximal inhibitory concentration: > 900000 nM
Compound 4: a limit, no number (the forecaster's own chance of this, stated with the estimate: 90%); the middle value is on the limit's open side.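

Compound 4 also gives only a limit, so none of its steps from compound 1, compound 2 or compound 3 can be read. The compounds shown leave open whether mirror images compound 3 and compound 4 differ at all in this assay.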